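Swapping the cyanophenyl for a pyrimidine on the cyclopropane

This account rests on a few compounds, and the source may have more. Where it says the series, first, only, none or still open, it means among the compounds named here.

Compound 3 `CC[C@H](C)[C@H](N)CN(C(=O)[C@@H]1C[C@H]1c1ccc(C#N)cc1)c1ccc(-c2ccccc2)cc1` gives in a functional assay for agonist activity at G protein-coupled receptor 88 (Homo sapiens), read by HTRF and cAMP accumulation (a lower number here means that less compound is needed, a higher number that more compound is needed for the effect), only a limit, > 25000 nM, and a further entry for it carries no single number. Its neighbours do have numbers: compound 1 `CC[C@H](C)[C@H](N)CN(C(=O)[C@@H]1C[C@H]1c1ccccc1)c1ccc(-c2ccccc2)cc1` gives 230 nM; 800 nM (2 entries), and compound 2 `CC[C@H](C)[C@H](N)CN(C(=O)[C@@H]1C[C@H]1c1ccccc1F)c1ccc(-c2ccccc2)cc1` gives 650 nM. Among the measured compounds shown here, the only step that reaches compound 3 is an at least 38-fold higher number from compound 2 to compound 3 (1.58 log units; beyond the scatter); its size rests on the limit of > 25000 nM in this assay, at which 1 of the 3 values shown sits, and is therefore known only as a least size, while the repeats of compound 1 the several entries of compound 1 in this assay, 230 nM; 800 nM (2 entries) show how far such numbers move on their own.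

Compound 4 `CC[C@H](C)[C@H](N)CN(C(=O)[C@@H]1C[C@H]1c1ncccn1)c1ccc(-c2ccccc2)cc1` differs from compound 3 in one place: pyrimidin-2-yl in place of 4-cyanophenyl on a saturated ring carbon. For the measured compounds named here, no measured step shares this exact change. Going by the values given here, what bears on it is that the 4-cyanophenyl is the one aryl group that coincided with the limit (the limit of > 25000 nM in this assay, at which 1 of the 3 values shown sits), whereas the plain phenyl of compound 1 and the 2-fluorophenyl of compound 2 both gave numbers well inside the assay's range. On these data alone, removing the 4-cyanophenyl is thus expected to lower the number, though a pyrimidin-2-yl is untested here, so the estimated step of an at least 5.0-fold lower number from compound 3 to compound 4 (0.69 log units; beyond the scatter) is kept cautious. Compound 4 is therefore expected to give 5000 nM, within 800 nM to 25000 nM, with a real chance that it too returns only a limit.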

Compound 4, half-maximal effective concentration: 130 nM
For compound 4 the middle estimate is 38-fold (1.59 log units) above the measured one; measured number below the stated range.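

The saturated ring carbon of the cyclopropane need not carry a carbon-only aromatic ring: in this assay, pyrimidin-2-yl, a six-membered aromatic ring with 2 hetero atoms, gives a measured number where 4-cyanophenyl gave only a limit, a change read as an at least 190-fold lower number from compound 3 to compound 4 (2.28 log units; beyond the scatter). That step is known only as a least size, since one end of it is a limit of the assay: the limit of > 25000 nM in this assay, at which 1 of the 4 values shown sits. The change from the 2-fluorophenyl rests on two measured numbers and reads a 5.0-fold lower number from compound 2 to compound 4 (0.70 log units; beyond the scatter), while the comparison of compound 4 with the plain phenyl of compound 1 has only the printed values to go on, and those repeats lie far apart: the several entries of compound 1 in this assay, 230 nM; 800 nM (2 entries).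

Whether the lower number goes with the ring nitrogens or with the loss of the nitrile stays open, as the compounds shown cannot separate the two, and a pyridin-2-yl on the same ring carbon would bear on this. On these data alone, it also remains open how much the point of attachment of the ring counts, which a pyrimidin-5-yl would test.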